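One Group Exchanged: From Compound 2 to Compound 4

The source may report more compounds than this note shows. Statements on the series, on what has been measured and on what is new or still open speak of the compounds shown alone.

Of the compounds shown here, three have so far been measured in a functional assay on BGC-823 cells (Homo sapiens) for antiproliferative activity, read by MTT assay, tested at 5 uM; a higher number here means a stronger effect of the compound at the concentration tested, a lower number a weaker effect. Compound 1 `COc1cc(C(=O)N/N=C/c2ccccc2C(F)(F)F)cc(OC)c1OC` gives 35.6% in this assay. Compound 2 `COc1cc(C2=NN(C(C)=O)C(c3ccccc3C(F)(F)F)O2)cc(OC)c1OC` gives 34.8%, and compound 3 `COc1cc(C(=O)N/N=C/c2c(Cl)cccc2Cl)cc(OC)c1OC` gives 27.8%. Compound 2 holds the second highest of the three numbers, yet its nearest neighbour, compound 1, and its furthest neighbour, compound 3, both lie within the scatter of it, so the three compounds cannot be separated on these data.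

Compound 4 `COc1cc(C2=NN(C(C)=O)C(c3ccc(Cl)c([N+](=O)[O-])c3)O2)cc(OC)c1OC` has not yet been measured in this assay. It differs from compound 2 in one place: 4-chloro-3-nitrophenyl in place of 2-(trifluoromethyl)phenyl on a saturated ring carbon. For the measured compounds named here, no pair of measured compounds that differ in one place is available, so no measured step guides the expectation. The three measured values sit close together. A step no larger than the scatter is expected in this assay, in either direction. The value for compound 4 is estimated at 33%, with a range from 15% to 52%. The estimate for compound 4 implies an expected step of a number 1.8 percentage points lower from compound 2 to compound 4 (within the scatter).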

Compound 4, a percentage reported as inhibition, at one concentration (the size of the read-out at that concentration, not a potency): 0%
Beside the measured number, compound 4's estimate is 33 percentage points above it; the measured number lies below the stated range.
By their numbers in this assay, from the lowest: compound 4; then compounds 3, 2 and 1 (each within the scatter of the next).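

In this assay, putting 4-chloro-3-nitrophenyl in place of 2-(trifluoromethyl)phenyl on the saturated ring carbon gives a number 34.8 percentage points lower from compound 2 to compound 4 (beyond the scatter), the first step among these compounds that can be read as lying beyond the scatter. The earlier compounds shown here could not be separated and so gave no sign of what this position can do; this pair shows that, with the rest of the structure unchanged, the group on this carbon can make the difference between a clear read-out at the concentration tested and none. Nothing available explains this loss.

The compounds shown leave open whether the loss goes with the chlorine, with the nitro group, or with the departure of the trifluoromethyl group, as this one exchange alters all three together. They also leave open how compounds carrying an amine or a carboxylic acid on the phenyl ring at this carbon would behave.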